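The source may hold more compounds than are shown below. What is called first, only, known or untested is meant among the compounds shown, and "the series" means these compounds.

Measured so far in an assay on isolated protein for inhibition of myosin-2 (Bos taurus), read by spectrophotometry, with a stated time of 24 min; a higher number here means a weaker inhibitor, a lower number a stronger inhibitor: compound 1, `CCCCCC/N=C(\C)c1c(O)c2ccccc2oc1=O`, 2900 nM; compound 2, `C/C(=N\Nc1ccccc1)c1c(O)c2ccccc2oc1=O`, 27000 nM; compound 3, `CC/C(=N\Cc1ccccc1)c1c(O)c2ccccc2oc1=O`, >= 100000 nM.

In this assay compound 2 stands highest of the two numbers. Within the data shown here, the only step that reaches it, a 9.3-fold higher number from compound 1 to compound 2 (0.97 log units; beyond the scatter), came with anilino in place of hexyl on a double-bonded nitrogen. The value of compound 3 is a limit of the assay, not a number (the limit of >= 100000 nM in this assay, at which 1 of the 3 values shown sits).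

Compound 4, `C/C(=N\CC(C)C)c1c(O)c2ccccc2oc1=O`, differs from compound 2 by isobutyl in place of anilino on a double-bonded nitrogen. Among the measured compounds shown here, the one step that bears on this change is that from the hexyl to the anilino compound, which raised the number; the change here runs the other way, back to an alkyl chain, so a lower number is expected, though isobutyl is shorter than hexyl. Compound 4 is therefore estimated at 6000 nM (range 1500 nM to 30000 nM), an expected 4.5-fold lower number from compound 2 to compound 4 (0.65 log units; beyond the scatter).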

Compound 4, half-maximal inhibitory concentration: 34000 nM
Compound 4: middle estimate off by 5.7-fold (0.75 log units), on the low side, and the stated range ends below it.
By their numbers in this assay, from the lowest: compound 1; then compounds 2 and 4 (each within the scatter of the next). At a limit, above all of these: compound 3.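

In this assay the change on the double-bonded nitrogen stays within the scatter, with a 1.3-fold higher number from compound 2 to compound 4 (0.10 log units; within the scatter) as the step from anilino to isobutyl. An alkyl chain alone therefore does not restore the lower number of compound 1, as the change from hexyl to isobutyl shows a 12-fold higher number from compound 1 to compound 4 (1.07 log units; beyond the scatter) and so sets the hexyl group apart. Nothing at hand accounts for this result. As far as these compounds go, whether the number follows chain length stays open: a butyl or an octyl chain on this nitrogen would test that, and a terminal amine on the hexyl chain remains equally untested here.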